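Hydroxy for dimethylamino on the extended thioether amide

The source may hold more compounds than are shown below. What is called first, only, known or untested is meant among the compounds shown, and "the series" means these compounds.

The series shares one core carrying a thioether-linked amide of a dichloroaniline. Compound 2 `CN(C)CCCn1nc(Cc2nnc(SCC(=O)Nc3ccc(Cl)cc3Cl)n2C)c2ccccc2c1=O` bears a dimethylamino group on the chain at the aromatic nitrogen; in an assay on 32D cells for inhibition of interleukin-15 (Mus musculus), read by resazurin assay, with stated times of 30 min and 2.5 days, in the presence of a further agent that is not named here (on this read-out higher numbers stand for weaker inhibition and lower numbers for stronger inhibition), compound 2 gives 16700 nM. Compound 1 `Cn1c(Cc2nn(CCCO)c(=O)c3ccccc23)nnc1SCC(=O)Nc1ccc(Cl)cc1Cl` is the hydroxy analogue of compound 2. In this assay compound 1 reaches only a limit, > 30000 nM, which is not a number. The change is hydroxy in place of dimethylamino on a saturated chain carbon, three bonds along the chain from an aromatic nitrogen, and its step reads an at least 1.7-fold higher number from compound 2 to compound 1 (0.25 log units; that floor lies within the scatter); the step ends at the limit of > 30000 nM in this assay, at which 1 of the 3 values shown sits, so its true size is not resolved.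

Compound 3 `CN(C)CCCn1nc(Cc2nnc(SCCCCCCCC(=O)Nc3ccc(Cl)cc3Cl)n2C)c2ccccc2c1=O` carries the dimethylamino chain together with a longer thioether linker; in this assay compound 3 gives 3200 nM, a lower number than compound 2. How the core of compound 3 differs from that of compound 2 is not broken down here.

Compound 4 `Cn1c(Cc2nn(CCCO)c(=O)c3ccccc23)nnc1SCCCCCCCC(=O)Nc1ccc(Cl)cc1Cl` is not yet measured. It differs from compound 3 by hydroxy in place of dimethylamino on a saturated chain carbon, three bonds along the chain from an aromatic nitrogen, the same change that took compound 2 to compound 1, at the same place. The measured precedent points to a weaker inhibitor after the change, but only as a floor that lies within the scatter, and compound 3 starts far from the limit. The step from compound 3 to compound 4 is therefore expected to be a 2.0-fold higher number from compound 3 to compound 4 (0.31 log units; beyond the scatter), a modest worsening, resting on the step from compound 2 to compound 1 and on the value of compound 3, 3200 nM. Compound 4 is expected to give 6500 nM, with a likely range from 2500 nM to 20000 nM.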

Compound 4, half-maximal inhibitory concentration: > 30000 nM
Compound 4: no number, only a limit (the forecaster's own chance of this, stated with the estimate: 10%); middle value at least 4.6-fold (0.66 log units) away from the limit.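

On the longer thioether linker, hydroxy in place of dimethylamino gives an at least 9.3-fold higher number from compound 3 to compound 4 (0.97 log units; beyond the scatter) in this assay; this step ends at a limit of the assay, not a number, but unlike the floor on the shorter linker, it lies beyond the scatter. The direction is therefore the same on both cores, towards weaker inhibition with hydroxy, but this does not show that the change has the same size on each: the same change on two cores in this assay, an at least 1.7-fold higher number (0.25 log units; that floor lies within the scatter) from compound 2 to compound 1 and an at least 9.3-fold higher number (0.97 log units; beyond the scatter) from compound 3 to compound 4; the limit leaves it open whether they differ. Neither step has a known true size, and the hydroxy compounds provide no number against which the effect of the linker could be read: the limit of > 30000 nM in this assay, at which 2 of the 4 values shown sit.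

On these data alone, it remains open whether any hydroxy compound on these cores would give a readable value, and whether another end group on the same chain, such as a primary amine, a morpholine or a carboxylic acid, would stay clear of the limit. Also open, as far as these compounds go, is whether a shorter or longer chain between the aromatic nitrogen and the dimethylamino group would keep the inhibition seen with the 3-(dimethylamino)propyl chain.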